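Furan-3-yl for 4-bromophenyl in a dienone series

This account rests on a few compounds, and the source may have more. Where it says the series, first, only, none or still open, it means among the compounds named here.

Measured so far:
- compound 1, `CC1=C(/C=C/C(=O)/C=C/c2ccc(Br)cc2)C(C)(C)CCC1`: 20100 nM
- compound 2, `CC1=C(/C=C/C(=O)/C=C/c2ccc(Cl)c(Cl)c2)C(C)(C)CCC1`: 53500 nM

Both compounds were tested in a functional assay on MCF7 cells (Homo sapiens) for cytotoxicity, read by sulforhodamine B assay, with a stated time of 48 h; a higher number here means a weaker inhibitor, a lower number a stronger inhibitor. Compound 1 gives 20100 nM, and compound 2 gives 53500 nM. Of the two numbers, compound 1 has the lower one, and its gap to compound 2 lies beyond the usual scatter.

Compound 3, `CC1=C(/C=C/C(=O)/C=C/c2ccoc2)C(C)(C)CCC1`, has not yet been measured in this assay. It differs from compound 1 in one place: furan-3-yl in place of 4-bromophenyl on a double-bonded chain carbon bound to a double-bonded chain carbon. Going by the values given here, no measured pair here shows this kind of exchange, so the size of the step is uncertain. Since compound 2, which carries a different halogenated phenyl, already gives 53500 nM, the series appears to tolerate changes at this position only with a loss, and the expectation for the step from compound 1 to compound 3 is a modest rise, a 1.7-fold higher number from compound 1 to compound 3 (0.24 log units; within the scatter). Compound 3 is therefore estimated at 35000 nM, with a range from 12000 nM to 100000 nM.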

Compound 3, half-maximal inhibitory concentration: 100000 nM
Compound 3: the middle estimate sits 2.9-fold (0.46 log units) below what was measured, and the stated range covers the measured number.
By their numbers in this assay, from the lowest: compound 1; then compounds 2 and 3 (each within the scatter of the next).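

In this assay, putting furan-3-yl in place of 4-bromophenyl on a double-bonded chain carbon bound to a double-bonded chain carbon gives a 5.0-fold higher number from compound 1 to compound 3 (0.70 log units; beyond the scatter), so this exchange weakens the compound by more than the usual scatter. Going by these compounds alone, this is the first direct sign that the group at this position matters for the read-out, as the shared core stays the same across the pair. The exchange alters the ring size, brings in a ring oxygen and removes the bromine all at once, and no measurement available here explains the loss.

The compounds shown leave open which of these differences accounts for the step. An unsubstituted phenyl or a thiophen-3-yl at this place could help separate the contribution of the bromine from that of the ring.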